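The source may report more compounds than this note shows. Statements on the series, on what has been measured and on what is new or still open speak of the compounds shown alone.

Compound 1, `CC(C)N(Cc1cccc(OCCCCCC(=O)O)c1)C(=O)c1ccc(-c2ccncc2)cc1`, gives in an ADME assay on BJ cells (Homo sapiens) for cytotoxicity, read by CellTiter-Glo and resazurin assay, with a stated time of 72 h (on this read-out lower numbers stand for an effect already at smaller amounts and higher numbers for an effect only at larger amounts of compound), the value > 26000 nM, which is a limit of the assay and not a number.
Compound 2, `CC(C)COc1cccc(-c2ccc(C(=O)N(Cc3cccc(OCCCCCC(=O)O)c3)C(C)C)cc2)c1`, gives in this assay the value > 26000 nM, again a limit.
Compound 3, `CCOC(=O)CCCCCOc1cccc(CN(C(=O)c2ccc(-c3cccc(OCC(C)C)c3)cc2)C(C)C)c1`, gives in this assay the value > 26000 nM, also a limit.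

Compound 3 therefore stands at the limit, and no number separates it from the other two measured compounds. The step from compound 1 to compound 2, a step that the two limits leave unreadable from compound 1 to compound 2, and the step from compound 2 to compound 3, a step that the two limits leave unreadable from compound 2 to compound 3, both run between two limits and cannot be read in size or direction. Going by the values given here, the one piece of evidence on all three is the limit of > 26000 nM in this assay, at which 3 of the 3 values shown sit.

Compound 4, `CCOC(=O)CCCCCOc1cccc(CN(C(=O)c2ccc(-c3ccc(Cl)c(Cl)c3)cc2)C(C)C)c1`, is not yet measured. Its change from compound 3 is 3,4-dichlorophenyl in place of 3-(isobutoxy)phenyl on an aromatic carbon. Among the compounds with values here, no measured step bears on this change, and none of the measured steps has a readable size, so no direction can be taken from them; the expectation is that compound 4 sits at the limit as well. The step from compound 3 to compound 4 is estimated as a step that the limit leaves unreadable from compound 3 to compound 4. For compound 4 in this assay the estimate is 30000 nM, within a range from 10000 nM to 100000 nM.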

Compound 4, half-maximal effective concentration: > 26000 nM
Compound 4: a limit, no number (the forecaster's own chance of this, stated with the estimate: 75%); the middle value lies beyond the limit too.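

Compound 4 gives > 26000 nM in this assay, again a limit and not a number. Since compound 3 and compound 4 both sit at a limit, the step between them cannot be read in size or direction. The compounds shown leave open at what concentration, if any, each would affect these cells: the limit of > 26000 nM in this assay, at which 4 of the 4 values shown sit.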